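The source may report more compounds than this note shows. Statements on the series, on what has been measured and on what is new or still open speak of the compounds shown alone.

Measured so far in a functional assay on HepG2 cells (Homo sapiens) for cytotoxicity, read by sulforhodamine B assay, with a stated time of 24 h; on this read-out higher numbers stand for weaker inhibition and lower numbers for stronger inhibition
Compound 1 `Cc1ccc(/N=C2\C(=O)Nc3ccc(S(=O)(=O)N4CCOCC4)cc32)cc1` gives 12800 nM
Compound 2 `Cc1ccc(S(=O)(=O)N/N=C2\C(=O)Nc3ccc(S(=O)(=O)N4CCOCC4)cc32)cc1` gives 24700 nM

On these two numbers, compound 2 stands within the usual scatter of compound 1. Compound 3 `CC(=O)N/N=C1\C(=O)Nc2ccc(S(=O)(=O)N3CCOCC3)cc21` has not yet been measured. It carries acetyl in place of (4-methylphenyl)sulfonyl on an amine nitrogen. Among the measured compounds shown here, no measured step shows the size of such a change in this assay and so no shift beyond the scatter is expected, in either direction. The expected move is a 1.0-fold lower number from compound 2 to compound 3 (0.01 log units; within the scatter) and this remains only an estimate. Compound 3 is estimated at 24000 nM with an expected range from 9000 nM to 65000 nM for this measurement.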

Compound 3, half-maximal inhibitory concentration: 27500 nM
Compound 3: middle estimate off by 1.1-fold (0.06 log units), on the low side, within the range that was stated.
By their numbers in this assay, from the lowest: compounds 1, 2 and 3 (each within the scatter of the next, the first and the last beyond it).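

In this assay, acetyl in place of (4-methylphenyl)sulfonyl on an amine nitrogen gives a 1.1-fold higher number from compound 2 to compound 3 (0.05 log units; within the scatter) and so shows that this large change in group size, including loss of the aromatic ring, leaves the number within the scatter. Acetamido in place of 4-methylphenyl on a double-bonded nitrogen gives a 2.1-fold higher number from compound 1 to compound 3 (0.33 log units; beyond the scatter) and is the only step here beyond the scatter, though a modest one. Nothing available explains either step. Going by these compounds, whether a carboxylic acid, a basic amine or a longer chain on this nitrogen would move the number beyond the scatter remains open.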